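Benzyl in place of aryl on the ring nitrogen

The compounds below may be only part of what the source reports. "The series", "measured", "known", "first", "only" and "open" are said of these compounds alone.

Compound 1 `COc1ccc(NC(=O)c2cc(-c3sc(NC(=O)C(C)(C)C)nc3C)n(-c3ccc(Br)cc3)n2)cc1` carries a 4-bromophenyl on an aromatic nitrogen of the shared core. In an in vitro assay on FRT cells for binding affinity to Cystic fibrosis transmembrane conductance regulator (Homo sapiens), read by fluorescence, with a stated time of 20 h (a higher number here means that more compound is needed for the effect, a lower number that less compound is needed), compound 1 gives 3400 nM. Going by the values given here, this is the highest of the two numbers so far, yet the nearest neighbour, compound 2 `C=CCn1nc(C(=O)NCc2ccccc2)cc1-c1sc(NC(=O)C(C)(C)C)nc1C`, gives 3000 nM in this assay, and the gap between the two lies within the usual scatter, so no order between them can be read. Among the compounds with values here, compound 2 differs from compound 1 in more than one place, so no single-point step is available.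

Compound 3 `COc1ccc(NC(=O)c2cc(-c3sc(NC(=O)C(C)(C)C)nc3C)n(Cc3cc(Cl)ccc3OC)n2)cc1` is the next analogue: 5-chloro-2-methoxybenzyl in place of 4-bromophenyl on an aromatic nitrogen. Within the data shown here, no step between measured compounds covers a change of this kind. The two numbers show only that an aryl and an allyl on that nitrogen, with different amide partners, land close together. The expected step from compound 1 to compound 3 in this assay is therefore estimated as a 1.1-fold lower number from compound 1 to compound 3 (0.05 log units; within the scatter), not beyond the scatter, in no preferred direction. For compound 3 the estimate in this assay is 3000 nM, with a range from 1000 nM to 9000 nM.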

Compound 3, half-maximal effective concentration in the Cystic fibrosis transmembrane conductance regulator assay: 1000 nM
Compound 3: the middle estimate sits 3.0-fold (0.48 log units) above what was measured; the range from low to high includes it.
By their numbers in the Cystic fibrosis transmembrane conductance regulator assay, from the lowest: compound 3; then compounds 2 and 1 (each within the scatter of the next).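

Going by these compounds alone, in the Cystic fibrosis transmembrane conductance regulator assay, compound 1 gives 3400 nM and compound 3 gives 1000 nM and the aromatic nitrogen gives the first readable single-point step: 5-chloro-2-methoxybenzyl in place of 4-bromophenyl gives a 3.4-fold lower number from compound 1 to compound 3 (0.53 log units; beyond the scatter), so with the (4-methoxyphenyl)carbamoyl group held fixed, this position does respond to a change of group. In a physicochemical assay for lipophilicity, read by HPLC, measured as octanol-water partition (a higher number here means a more lipophilic compound, a lower number a more polar compound), compound 1 gives 5.52 and compound 3 gives 5.7 and the same change gives a number 0.18 log units higher from compound 1 to compound 3 (within the scatter), so no order between the two compounds can be read in that measurement, although they stand apart in the Cystic fibrosis transmembrane conductance regulator assay. The change replaces a ring set directly on the nitrogen with a benzyl, removes bromine, and brings in chlorine and a methoxy group with one hydrogen-bond acceptor, and nothing at hand bears on which of these features goes with the step.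

Open, on these data alone, is how much belongs to the benzyl itself and how much to its substituents, a question that an unsubstituted benzyl, a 5-chlorobenzyl or a 2-methoxybenzyl on the same nitrogen would address. Also open, as far as these compounds go, is how an amine or a carboxylic acid on that benzyl would behave, and steps involving compound 2 cannot be read, since it differs from the others in more than one place.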